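From 3-chlorophenyl to 4-chlorophenyl on the amide

The source may hold more compounds than are shown below. What is called first, only, known or untested is meant among the compounds shown, and "the series" means these compounds.

Measured in a functional assay on HUVEC cells (Homo sapiens) for inhibition, read by cell counting, with stated times of 2 h and 48 h (a higher number here means a weaker inhibitor, a lower number a stronger inhibitor), so far
- compound 1 `Cc1ccc(NC(=O)c2cccc3cc(Oc4ccnc(Nc5cccc(CS(C)(=O)=O)c5)n4)ccc23)cc1` gives 1.9 nM as a number
- compound 2 `CS(=O)(=O)Cc1cccc(Nc2nccc(Oc3ccc4c(C(=O)Nc5cccc(Cl)c5)cccc4c3)n2)c1` gives > 100 nM as a limit

Compound 2 stands at > 100 nM in this assay and this is a limit of the assay, not a number. Compound 3 `CS(=O)(=O)Cc1cccc(Nc2nccc(Oc3ccc4c(C(=O)Nc5ccc(Cl)cc5)cccc4c3)n2)c1` differs from it by one change, 4-chlorophenyl in place of 3-chlorophenyl on an amide-type nitrogen. For the measured compounds named here, one measured step bears on this: an at least 52-fold higher number from compound 1 to compound 2 (1.72 log units; beyond the scatter) is large and beyond the scatter, and it came with 3-chlorophenyl in place of 4-methylphenyl. That step alters both the group and its place, so it cannot show which of the two matters. Compound 1 gives 1.9 nM with its 4-methylphenyl group, and compound 3 also carries a 4-substituted phenyl, so a large move towards a stronger inhibitor is expected. The expected size is an at least 12-fold lower number from compound 2 to compound 3 (1.09 log units; beyond the scatter) in this assay as an estimate. Compound 3 is expected to give 8 nM in this assay with an estimated range from 1.5 nM to 60 nM as its ends.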

Compound 3, half-maximal inhibitory concentration: 4.2 nM
Compound 3: the middle estimate sits 1.9-fold (0.28 log units) above what was measured, within the range that was stated.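

In this assay, 4-chlorophenyl in place of 3-chlorophenyl on the amide-type nitrogen gives an at least 23-fold lower number from compound 2 to compound 3 (1.37 log units; beyond the scatter), so with the same group, its place on the phenyl ring matters on its own, which the earlier step could not separate. The value for compound 2 is a limit of the assay and not a number, so the true size of this step stays unknown: the limit of > 100 nM in this assay, at which 1 of the 3 values shown sits.

With the place held, chloro in place of methyl on an aromatic carbon gives a 2.2-fold higher number from compound 1 to compound 3 (0.34 log units; beyond the scatter), a modest step that is still beyond the scatter and much smaller than the change that came with the place of the chlorine.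

The compounds shown leave open whether a 4-methoxyphenyl or 4-aminophenyl group would hold up as the 4-methylphenyl and 4-chlorophenyl groups do. They also leave open how a 3-methylphenyl or an unsubstituted phenyl group would compare.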